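Carbamate Replaces Chlorophenoxypropyl Ether at Compound 3

The source may hold more compounds than are shown below. What is called first, only, known or untested is meant among the compounds shown, and "the series" means these compounds.

Compound 1 `CC(C)=CCOc1cc(=O)n(CCCO)c2c1CC(CC=C(C)C)C(C)(C)C2`: 20.7%
Compound 2 `CC(C)=CCC1Cc2c(OCCCNC(=O)c3ccco3)cc(=O)n(CCCO)c2CC1(C)C`: 2.1%
Compound 3 `CC(C)=CCC1Cc2c(OCCCOc3ccc(Cl)cc3)cc(=O)n(CCCO)c2CC1(C)C`: 22.7%

In a functional assay on PANC-1 cells (Homo sapiens) for inhibition, read by MTT assay, with a stated time of 24 h, tested at 10 uM (a higher number here means more inhibition at the concentration tested (going by the name of the read-out), a lower number less inhibition), compound 3 gives the highest of the three numbers, though compound 1 sits within the scatter of it; compound 2 lies a number 20.6 percentage points higher from compound 2 to compound 3 (beyond the scatter). Compound 4 `COc1cccc(NC(=O)Oc2cc(=O)n(CCCO)c3c2CC(CC=C(C)C)C(C)(C)C3)c1` carries (3-methoxyphenyl)carbamoyl in place of 3-(4-chlorophenoxy)propyl on an oxygen on an aromatic ring. For the measured compounds named here, two measured steps bear on it: a number 2 percentage points higher from compound 1 to compound 3 (within the scatter), and a number 18.6 percentage points lower from compound 1 to compound 2 (beyond the scatter). Both steps vary the group on this oxygen, and the one bearing an amide fell modestly while the aryl ether stayed level. The carbamoyl group of compound 4 resembles neither closely, so a small downward step is expected at most, a number 7.7 percentage points lower from compound 3 to compound 4 (within the scatter). Compound 4 is therefore estimated at 15%, within 0% to 35%.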

Compound 4, a percentage reported as inhibition, at one concentration (the size of the read-out at that concentration, not a potency): 16.2%
The estimate for compound 4 lay 1.2 percentage points below the measured number; low and high end bracket the measured number.
By their numbers in this assay, from the lowest: compound 2; then compounds 4, 1 and 3 (each within the scatter of the next).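

In this assay the (3-methoxyphenyl)carbamoyl group on this oxygen stays level with both ether groups, with a number 6.5 percentage points lower from compound 3 to compound 4 (within the scatter) and with a number 4.5 percentage points lower from compound 1 to compound 4 (within the scatter) as well. It stands apart from the amide-bearing chain, with a number 14.1 percentage points higher from compound 2 to compound 4 (beyond the scatter) so a nitrogen-bearing group here does not by itself bring the number down, and compound 2 alone goes against the level run of compounds 1, 3 and 4.

As far as these compounds go, whether an amine or a carboxylic acid at the end of a propyl chain on this oxygen would read like compound 2 or like the others stays open. No measurement shown explains these differences.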